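The compounds below may be only part of what the source reports. "The series", "measured", "known", "first", "only" and "open" are said of these compounds alone.

Of the compounds shown here, three with a shared core have been tested in a functional assay on MDA-MB-231 cells (Homo sapiens) for cytotoxicity, read by MTT assay; a lower number here means a stronger inhibitor, a higher number a weaker inhibitor. Compound 1, `COc1cc(-n2cc(-c3ccc(N)cc3)nn2)cc(OC)c1OC`, gives > 10000 nM, which is a limit of the assay rather than a number. Compound 3, `COc1cc(-c2cn(-c3cc(OC)c(OC)c(OC)c3)nn2)cc(OC)c1OC`, likewise gives > 10000 nM, again a limit. For the measured compounds named here, compound 2, `COc1ccc(-c2cn(-c3ccc(Oc4ccccc4)cc3)nn2)cc1OC`, is the one compound with a number: in this assay compound 2 gives 10000 nM. That number sits at the limit of > 10000 nM in this assay, at which 2 of the 3 values shown sit, so compound 2 stands at the edge of what the assay can report, and nothing here separates it clearly from compound 1 or compound 3.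

Compound 4, `COc1ccc(-c2cn(-c3ccc(Oc4ccccc4)cc3)nn2)cc1`, has not yet been measured. It differs from compound 2 in one place: hydrogen in place of methoxy on an aromatic carbon. Going by the values given here, no measured pair shows what this change does, so the expectation rests on where compound 2 already stands. Compound 4 is expected to be a weak inhibitor, with a step from compound 2 to compound 4 of a 1.5-fold higher number from compound 2 to compound 4 (0.18 log units; within the scatter), which is within the scatter. The estimate for compound 4 in this assay is 15000 nM, between 5000 nM and 50000 nM, with a good chance that the assay reports only a limit.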

Compound 4, half-maximal inhibitory concentration: > 100 nM
Compound 4 gave a limit, no number; the forecaster's own chance of this, stated with the estimate: 60%; the middle value does not contradict the limit.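

In this assay compound 4 gives > 100 nM, which is a limit and not a number, so the step between compound 2 and compound 4 cannot be read. The compounds shown leave open whether hydrogen in place of methoxy on an aromatic carbon changes inhibition at all.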